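Shortening the acid arm of a pyridyl-stilbene thromboxane synthase inhibitor

The source may report more compounds than this note shows. Statements on the series, on what has been measured and on what is new or still open speak of the compounds shown alone.

Measured so far:
Compound 1, `CC(C)(O)C(CCC/C=C(\c1ccccc1)c1cccnc1)C(=O)O`, gives 42 nM.
Compound 2, `CCOC(=O)CCCC/C=C(\c1ccccc1)c1cccnc1`, gives 600 nM.
Compound 3, `CC(C)(CCC/C=C(\c1ccccc1)c1cccnc1)C(=O)O`, gives 21 nM.

These three compounds were compared in an assay (Equus caballus) for inhibition of Thromboxane-A synthase (Homo sapiens), using microsomes; a lower number here means a stronger inhibitor, a higher number a weaker inhibitor. Compound 3 has the lowest number of the three, but its nearest neighbour is compound 1, and the step of a 2.0-fold lower number from compound 1 to compound 3 (0.30 log units; within the scatter) lies within the scatter, so the two cannot be ranked. Compound 2 stands far away: a 29-fold lower number from compound 2 to compound 3 (1.46 log units; beyond the scatter).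

Compound 4, `O=C(O)CCC/C=C(\c1ccccc1)c1cccnc1`, is the unmeasured compound. Its change from compound 3 is carboxy in place of 1-carboxy-1-methylethyl on a saturated chain carbon, three bonds along the chain from a double-bonded chain carbon. Among the compounds with values here, no measured step reproduces this change exactly. The large step from compound 2 to compound 3 exchanged an ethyl ester for a free acid alongside the two methyl groups, so it offers only a loose guide; the step from compound 1 to compound 3, which trimmed the acid-bearing group without removing the methyls, showed nothing beyond the scatter. Since compound 4 keeps the carboxy group of compound 3 but loses the two methyl groups, a modest weakening is expected, estimated as a 2.1-fold higher number from compound 3 to compound 4 (0.33 log units; beyond the scatter). The expected value for compound 4 in this assay is 45 nM, with a range from 12 nM to 160 nM.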

Compound 4, half-maximal inhibitory concentration: 30 nM
The estimate for compound 4 lay 1.5-fold (0.18 log units) above the measured number; measured number inside the range.
By their numbers in this assay, from the lowest: compounds 3, 4 and 1 (each within the scatter of the next); then compound 2.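

In this assay, carboxy in place of 1-carboxy-1-methylethyl, on a saturated chain carbon three bonds along the chain from a double-bonded chain carbon, gives a step within the scatter (from a 1.4-fold higher number from compound 3 to compound 4 (0.15 log units; within the scatter)), so the two compounds cannot be ranked and the larger group shows no measurable advantage here. The hydroxy-bearing group of compound 1 cannot be told apart from carboxy either (from a 1.4-fold lower number from compound 1 to compound 4 (0.15 log units; within the scatter)). The wide gap to the ethyl ester now also appears with a plain carboxy group (from a 20-fold lower number from compound 2 to compound 4 (1.30 log units; beyond the scatter)), so among these compounds it does not depend on the methyl groups of compound 3 or on the hydroxy group of compound 1. No measurement shown gives a reason for these numbers.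

From the compounds shown here alone, compound 2 differs from compound 4 in both its ester and its chain length, so the share of each in that gap remains open. Also open, going by these compounds, is how an ethyl ester on the chain of compound 4, a primary amide or a tetrazole in place of the carboxylic acid, or a longer chain ending in a plain carboxylic acid would compare.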